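Adding a nitro group to compound 3

The source may report more compounds than this note shows. Statements on the series, on what has been measured and on what is new or still open speak of the compounds shown alone.

Three compounds measured so far in an ADME assay on HEL cells (Homo sapiens) for cytotoxicity; a higher number here means that more compound is tolerated, a lower number that less compound is tolerated
- compound 1 `O=C(COc1cccc2ccccc12)N/N=C/c1cccc(O)c1` gives 62.7 ug/mL
- compound 2 `C/C(=N\NC(=O)COc1cccc2ccccc12)c1ccc(C#N)cc1Br` gives 12.7 ug/mL
- compound 3 `C/C(=N\NC(=O)COc1cccc2ccccc12)c1ccccc1` gives 20 ug/mL

Compound 3 at 20 ug/mL lies within the scatter of compound 2 at 12.7 ug/mL while compound 1 at 62.7 ug/mL stands clearly higher than both. Compound 4 `C/C(=N\NC(=O)COc1cccc2ccccc12)c1ccc([N+](=O)[O-])cc1` keeps everything in compound 3 except for one change nitro in place of hydrogen on an aromatic carbon in which nitro takes the place of hydrogen on an aromatic carbon, para to a large group. Within the data shown here, no measured compound carries a nitro group, so the data offer no direct precedent. Among the measured compounds shown here, the one measured step that alters the groups on this aromatic ring is a 1.6-fold higher number from compound 2 to compound 3 (0.20 log units; within the scatter) and it offers no sign of a large effect from such a change. Compound 1 differs from compound 3 in more than one place, so its gap gives no size for this change. No step beyond the scatter is therefore expected in this assay and no firm direction can be given. The estimated step is a 1.1-fold lower number from compound 3 to compound 4 (0.05 log units; within the scatter) and remains an expectation only. For compound 4 the estimated value is 18 ug/mL with an expected range from 7 ug/mL to 50 ug/mL in this measurement.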

Compound 4, half-maximal cytotoxic concentration: > 100 ug/mL
Compound 4 ended at the assay's limit; the forecaster's own chance of this, stated with the estimate: 10%; middle value at least 5.5-fold (0.74 log units) from the limit.
By their numbers in this assay, from the lowest: compounds 2 and 3 (each within the scatter of the next); then compound 1. At a limit, above all of these: compound 4.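

In this assay compound 4 gives > 100 ug/mL, which is a limit of the assay and not a number. Placed on an aromatic carbon para to a large group, nitro in place of hydrogen gives an at least 5.0-fold higher number from compound 3 to compound 4 (0.69 log units; beyond the scatter), so a single added group at this position can move the number beyond the scatter, which the earlier compounds had not shown for this ring. The exchange of 2-bromo-4-cyanophenyl for 4-nitrophenyl likewise gives an at least 7.8-fold higher number from compound 2 to compound 4 (0.89 log units; beyond the scatter), whereas the exchange of that same group for phenyl gave only a 1.6-fold higher number from compound 2 to compound 3 (0.20 log units; within the scatter), so on this core the ring substituents are not always without consequence in this assay.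

From the compounds shown here alone, with compound 4 at a limit, both new steps give only a lower bound, and their full size stays unknown. The compounds shown also leave open whether the rise belongs to nitro itself or would also come with another group at this place, such as an amine or a carboxylic acid, and whether nitro would do the same on the core of compound 1.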